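Removing One Fluorine from the Sulfonamide Aryl Group

The compounds below may be only part of what the source reports. "The series", "measured", "known", "first", "only" and "open" are said of these compounds alone.

Of the compounds shown here, two have been measured in an assay on isolated protein for inhibition of protein deacetylase HDAC6 (Homo sapiens), read by mobility shift assay; on this read-out lower numbers stand for stronger inhibition and higher numbers for weaker inhibition. Compound 1 `CN(C)c1ccc(CN(Cc2ccc(C(=O)NO)cc2)S(=O)(=O)c2c(F)c(F)c(F)c(F)c2F)cc1` gives 29 nM, and compound 2 `O=C(NO)c1ccc(CN(Cc2ccncc2)S(=O)(=O)c2c(F)c(F)c(F)c(F)c2F)cc1` gives 14 nM. Among the compounds with values here, the single change between them, pyridin-4-yl in place of 4-(dimethylamino)phenyl on a saturated chain carbon bound to a sulfonamide nitrogen, produces a 2.1-fold lower number from compound 1 to compound 2 (0.32 log units; beyond the scatter). Within the data shown here, on the numbers so far, compound 2 stands lowest of the two, with compound 1 as its only neighbour.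

Compound 3 `O=C(NO)c1ccc(CN(Cc2ccncc2)S(=O)(=O)c2cc(F)c(F)c(F)c2F)cc1` differs from compound 2 in one place: hydrogen in place of fluoro on an aromatic carbon, so that 2,3,4,5,6-pentafluorophenyl becomes 2,3,4,5-tetrafluorophenyl. Among the measured compounds shown here, no measured step alters this part of the molecule; the one known step, between compound 1 and compound 2, concerns a different part and gives no guidance here. Without a precedent, the expectation for compound 3 in this assay is a step of no size beyond the scatter, a 1.4-fold higher number from compound 2 to compound 3 (0.15 log units; within the scatter), in either direction. Compound 3 is therefore estimated at 20 nM, with a range from 7 nM to 60 nM.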

Compound 3, half-maximal inhibitory concentration: 11 nM
Compound 3: middle estimate off by 1.8-fold (0.26 log units), on the high side; measured number inside the range.
By their numbers in this assay, from the lowest: compounds 3 and 2 (each within the scatter of the next); then compound 1.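

In this assay the swap of 2,3,4,5,6-pentafluorophenyl for 2,3,4,5-tetrafluorophenyl gives a 1.3-fold lower number from compound 2 to compound 3 (0.10 log units; within the scatter) and so leaves compound 2 and compound 3 indistinguishable. Within the data shown here, this is the first reading on the sulfonamide aryl group, since the earlier step concerned a different part of the molecule, and it shows that this aromatic carbon, ortho to a fluoro group and ortho to a large group, can carry hydrogen or fluoro without a readable difference, at least with pyridin-4-yl on the sulfonamide nitrogen. No measurement at hand bears on why the two compounds match so closely.

Open, as far as these compounds go, is whether this aromatic carbon would accept something bigger than a fluoro group, such as a methyl or methoxy group, and whether the aryl group could lose further fluoro groups, down to plain phenyl, and keep a similar number. Also open, from the compounds shown here alone, is whether the same hydrogen-for-fluoro swap would read the same way in the compound 1 series, which carries 4-(dimethylamino)phenyl on the sulfonamide nitrogen instead of pyridin-4-yl.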